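This account rests on a few compounds, and the source may have more. Where it says the series, first, only, none or still open, it means among the compounds named here.

Measured compounds:
- compound 1, `Cc1cc(N(C)C)nc2ccc(NC(=O)c3ccc(Cl)c(Cl)c3)cc12`: 33300 nM
- compound 2, `CCN1CCN(c2cc(C)c3cc(NC(=O)c4ccc(OC)cc4)ccc3n2)CC1`: 7690 nM

Working notes on the series. Two amides on the shared core have been measured in a functional assay on MCF7 cells (Homo sapiens) for antiproliferative activity, read by MTT assay, with a stated time of 72 h; on this read-out higher numbers stand for weaker inhibition and lower numbers for stronger inhibition. Compound 1 gives 33300 nM and stands at the higher of the two numbers. Compound 2 gives 7690 nM, a lower number than that of compound 1, a gap beyond the scatter; compound 2 differs from compound 1 in more than one place, so the two values are noted side by side and nothing more is read from them.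

Compound 3, `Cc1cc(N2CCCC2)nc2ccc(NC(=O)c3ccc(Cl)c(Cl)c3)cc12`, is the next compound to go into this assay. It differs from compound 1 in one place: pyrrolidin-1-yl in place of dimethylamino on an aromatic carbon. Within the data shown here, no measured pair in this set isolates such a change, so there is no step to lean on. Given the size of the replacement, the step from compound 1 to compound 3 is expected to be small, a 1.3-fold lower number from compound 1 to compound 3 (0.12 log units; within the scatter), with no clear direction and most likely within the scatter. On that basis compound 3 is estimated at 25000 nM, with a range from 8000 nM to 80000 nM.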

Compound 3, half-maximal inhibitory concentration: 26300 nM
The estimate for compound 3 lay 1.1-fold (0.02 log units) below the measured number, and the stated range covers the measured number.
By their numbers in this assay, from the lowest: compound 2; then compounds 3 and 1 (each within the scatter of the next).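

Working notes on the series. In this assay, among these compounds, pyrrolidin-1-yl in place of dimethylamino on the aromatic carbon next to the ring nitrogen gives a 1.3-fold lower number from compound 1 to compound 3 (0.10 log units; within the scatter) and so gives the first step in this set that isolates a single change. With the rest of the structure held fixed, this assay does not separate the open dimethylamino group from the five-membered ring of pyrrolidin-1-yl, so enlarging the group in this way leaves the read-out within the usual scatter. No measurement bearing on the reason for this result is at hand.

From the compounds shown here alone, the pair covers only these two tertiary amine groups at this carbon, so it remains open whether morpholin-4-yl, piperidin-1-yl or a primary amine there would also stay within the scatter of compound 1. Going by these compounds, it also remains open whether a group without a nitrogen on this carbon, such as methoxy or a longer alkyl chain, would shift the number beyond the scatter.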